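The source may hold more compounds than are shown below. What is called first, only, known or untested is meant among the compounds shown, and "the series" means these compounds.

Compound 1 `Cc1ccc(NC2=CC(=O)c3c(nc4n3[C@H]3OC[C@@H](O)[C@H]3OC4)C2=O)cc1`, compound 2 `COc1ccccc1NC1=CC(=O)c2c(nc3n2[C@H]2OC[C@@H](O)[C@H]2OC3)C1=O` and compound 3 `O=C1C(Nc2ccc(C(F)(F)F)cc2)=CC(=O)c2c1nc1n2[C@H]2OC[C@@H](O)[C@H]2OC1` share one core and differ only in the aromatic group on an amine nitrogen. In a functional assay on MGC-803 cells (Homo sapiens) for inhibition, read by sulforhodamine B assay (a higher number here means a weaker inhibitor, a lower number a stronger inhibitor), compound 1 gives 1550 nM, compound 2 gives 1670 nM and compound 3 gives 1860 nM. Compound 3 thus stands level with the other two, within the scatter of both.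

Compound 4 `CCOc1ccccc1NC1=CC(=O)c2c(nc3n2[C@H]2OC[C@@H](O)[C@H]2OC3)C1=O` has not yet been measured. It differs from compound 3 in that same place: 2-ethoxyphenyl in place of 4-(trifluoromethyl)phenyl on an amine nitrogen. Put simply, this is 2-ethoxyphenyl in place of 4-(trifluoromethyl)phenyl on an amine nitrogen.

The closest guide is compound 2, which carries 2-methoxyphenyl where compound 4 carries 2-ethoxyphenyl. Its step to compound 3 is a 1.1-fold higher number from compound 2 to compound 3 (0.05 log units; within the scatter). The other two measured steps, a 1.1-fold higher number from compound 1 to compound 2 (0.03 log units; within the scatter) and a 1.2-fold higher number from compound 1 to compound 3 (0.08 log units; within the scatter), also stay within the scatter. None of the three measured compounds carries an ethoxy group, so this evidence is indirect. Even so, no step beyond the scatter is expected in this assay. The estimated change is a 1.1-fold lower number from compound 3 to compound 4 (0.04 log units; within the scatter). For compound 4 the expected value is 1700 nM, with an estimated range from 950 nM to 3000 nM.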

Compound 4, half-maximal inhibitory concentration: 2830 nM
Compound 4: middle estimate off by 1.7-fold (0.22 log units), on the low side; measured number inside the range.
By their numbers in this assay, from the lowest: compounds 1, 2, 3 and 4 (each within the scatter of the next).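

Adding one methyl to the chain of the 2-methoxyphenyl group is the smallest change in this set, and it gives a 1.7-fold higher number from compound 2 to compound 4 (0.23 log units; within the scatter) in this assay. Exchanging the whole aromatic group on the amine nitrogen gives a 1.5-fold higher number from compound 3 to compound 4 (0.18 log units; within the scatter) and a 1.8-fold higher number from compound 1 to compound 4 (0.26 log units; within the scatter), so the 2-ethoxyphenyl group joins the other three aromatic groups, and every pair among the four compounds remains within the scatter. Thus, an ethoxy chain, absent from the earlier compounds, produces no step beyond the scatter in this series, and nothing shown here offers an explanation for the size of these steps.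

The compounds shown carry only substituted phenyl groups on this nitrogen, so it remains open whether a propoxy chain in place of the ethoxy, or an amine or a carboxylic acid on the phenyl ring, would produce a step beyond the scatter. On these data alone, it is also open whether replacing the phenyl ring altogether with a saturated ring such as cyclohexyl would leave the number within the scatter of these four compounds.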